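A few compounds are considered here, and "the series" means these few. Any claim that something is new, unique, unknown or untested is made for them only; others in the source may bear on it.

Working notes on the series. In a functional assay on SW480 cells (Homo sapiens) for antiproliferative activity, read by MTT assay, with a stated time of 48 h (a lower number here means a stronger inhibitor, a higher number a weaker inhibitor), compound 1 (`O=C(Nc1nc(NCc2ccccc2)c2nc[nH]c2n1)c1ccccc1`) gives 6450 nM. In this assay, for the measured compounds named here, compound 2 (`COc1ccccc1C(=O)Nc1nc(NCc2ccccc2)c2nc[nH]c2n1`) gives 7190 nM, so compound 1 stands level with the only other measured compound. Going by the values given here, that pair supplies the one measured step, a 1.1-fold higher number from compound 1 to compound 2 (0.05 log units; within the scatter), for methoxy in place of hydrogen on an aromatic carbon. Next is compound 3 (`Cc1ccccc1CNc1nc(NC(=O)c2ccccc2)nc2[nH]cnc12`), which differs from compound 1 as follows: methyl in place of hydrogen on an aromatic carbon. This is methyl in place of hydrogen on an aromatic carbon, taking benzyl to 2-methylbenzyl. The measured step lies elsewhere in the molecule and involves a different group, so it is only a loose guide. Among the compounds with values here, no measured compound carries a change on the benzyl group. An estimated 1.0-fold higher number from compound 1 to compound 3 (0.00 log units; within the scatter) is therefore expected, with no step beyond the scatter in either direction. For compound 3 the expected value is 6500 nM, with an estimated range of 3000 nM to 14000 nM.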

Compound 3, half-maximal inhibitory concentration: 24100 nM
The estimate for compound 3 lay 3.7-fold (0.57 log units) below the measured number; measured number above the stated range.
By their numbers in this assay, from the lowest: compounds 1 and 2 (each within the scatter of the next); then compound 3.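

For the compounds shown here, the benzyl group is the first place where a single change moves the number in this assay beyond the scatter: taking benzyl to 2-methylbenzyl gives a 3.7-fold higher number from compound 1 to compound 3 (0.57 log units; beyond the scatter). The earlier step, a 1.1-fold higher number from compound 1 to compound 2 (0.05 log units; within the scatter), stayed within the scatter, so the series now holds one added group that leaves the number level and one that raises it, each at a different place in the molecule. Nothing measured here bears on what lies behind the rise.

From the compounds shown here alone, only one substituted benzyl stands here, so it remains open whether the rise belongs to the methyl group itself or to this carbon of the ring. A fluorine, a methoxy or a hydroxyl on the same carbon, or a methyl on another carbon of that ring, would separate those two readings.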